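The compounds below may be only part of what the source reports. "The series", "measured", "known", "first", "only" and "open" are said of these compounds alone.

Compound 3 `O=S(=O)(NCCCNCc1ccccc1)c1cc(C(F)(F)F)cc(C(F)(F)F)c1` carries a plain benzyl group on its amine nitrogen. Among the measured compounds shown here, in a functional assay on ASPC1 cells (Homo sapiens) for inhibition, read by MTT assay, with a stated time of 72 h (on this read-out higher numbers stand for weaker inhibition of growth and lower numbers for stronger inhibition of growth), compound 3 gives 13000 nM, the second highest of the three numbers measured so far. Its nearest neighbour is compound 1 `O=S(=O)(NCCCNCc1ccc(Cl)c(C(F)(F)F)c1)c1cc(C(F)(F)F)cc(C(F)(F)F)c1`, which gives 9600 nM; the gap, a 1.4-fold higher number from compound 1 to compound 3 (0.13 log units; within the scatter), is too small to count as a real change. Further off stands compound 2 `CN(CCCNS(=O)(=O)c1cc(C(F)(F)F)cc(C(F)(F)F)c1)Cc1ccccc1`, with a methyl on the amine nitrogen, which gives 51000 nM; taking that methyl away, a 3.9-fold lower number from compound 2 to compound 3 (0.59 log units; beyond the scatter), brought a modest gain in growth inhibition.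

Compound 4 `O=S(=O)(NCCCNCc1ccc(Cl)cc1)c1cc(C(F)(F)F)cc(C(F)(F)F)c1` differs from compound 3 by chloro in place of hydrogen on an aromatic carbon, sitting para to a large group. For the measured compounds named here, the only measured step that speaks to this change is the one between compound 1 and compound 3, where a more heavily substituted ring on the same carbon moved the number by no more than the scatter. A step of similar size, or none at all, is therefore expected, leaning if anything toward stronger inhibition. Compound 4 is expected to give 11000 nM, with a range from 5000 nM to 25000 nM. That estimate would mean a 1.2-fold lower number from compound 3 to compound 4 (0.07 log units; within the scatter).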

Compound 4, concentration for 50% growth inhibition: 3000 nM
Compound 4: middle estimate off by 3.7-fold (0.56 log units), on the high side, outside the stated range (below it).
By their numbers in this assay, from the lowest: compound 4; then compounds 1 and 3 (each within the scatter of the next); then compound 2.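

In this assay this position responds to a single atom: chloro in place of hydrogen gives a 4.3-fold lower number from compound 3 to compound 4 (0.64 log units; beyond the scatter) and makes compound 4 the strongest inhibitor of growth so far, something the ring of compound 1, with its added trifluoromethyl, did not reveal. Adding that trifluoromethyl to the chlorinated ring gives the gain back, since hydrogen in its place gives a 3.2-fold lower number from compound 1 to compound 4 (0.51 log units; beyond the scatter) and the two changes at the amine and on the ring together span a 17-fold lower number from compound 2 to compound 4 (1.23 log units; beyond the scatter) as the widest step in this small set. Nothing measured here accounts for these steps. As far as these compounds go, whether fluoro, bromo or methoxy on the same aromatic carbon would match chloro remains open. So does whether chloro would bring a similar gain with a longer chain in the core.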